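The source may report more compounds than this note shows. Statements on the series, on what has been measured and on what is new or still open speak of the compounds shown alone.

Measured in a functional assay on COLO 205 cells (Homo sapiens) for inhibition, read by sulforhodamine B assay, with a stated time of 48 h; a higher number here means a weaker inhibitor of growth, a lower number a stronger inhibitor of growth:
- compound 1 `Cc1ccc(C2=NN(c3ccc(S(C)(=O)=O)cc3)C(=O)CC2)cc1`: 520 nM
- compound 2 `Cc1cc(O)ccc1C1=NN(c2ccc(S(C)(=O)=O)cc2)C(=O)CC1`: 6620 nM

Of these two compounds, compound 2 has the higher number, 6620 nM, which makes it the weaker inhibitor of growth of the pair. The next compound to consider is compound 3 `CCc1ccc(C2=NN(c3ccc(S(C)(=O)=O)cc3)C(=O)CC2)cc1`, which differs from compound 2 in one place: 4-ethylphenyl in place of 4-hydroxy-2-methylphenyl on a carbon with a double bond to nitrogen. The change sits on a carbon with a double bond to nitrogen, in a six-membered non-aromatic ring with 2 nitrogen.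

Among the compounds with values here, only one measured step bears on this change. It is a 13-fold higher number from compound 1 to compound 2 (1.10 log units; beyond the scatter), a large step in which 4-hydroxy-2-methylphenyl took the place of 4-methylphenyl. Compound 3 leaves 4-hydroxy-2-methylphenyl behind again, and its 4-ethylphenyl differs from the 4-methylphenyl of compound 1 only in having ethyl where that group has methyl. Within the data shown here, no measured pair shows what that last swap does, so the expectation carries real uncertainty. A large step to a lower number in this assay is expected, roughly undoing the measured one. The estimated step is an 11-fold lower number from compound 2 to compound 3 (1.04 log units; beyond the scatter). For compound 3 the estimate is 600 nM, with an expected range from 200 nM to 1800 nM.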

Compound 3, concentration for 50% growth inhibition: 1020 nM
Beside the measured number, compound 3's estimate is 1.7-fold (0.23 log units) below it; low and high end bracket the measured number.
By their numbers in this assay, from the lowest: compounds 1 and 3 (each within the scatter of the next); then compound 2.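

In this assay the replacement of 4-hydroxy-2-methylphenyl by 4-ethylphenyl gives a 6.5-fold lower number from compound 2 to compound 3 (0.81 log units; beyond the scatter) and shows that the weaker result of compound 2 does not apply to every group on this carbon of the shared core. The comparison with the methyl-bearing parent gives a 2.0-fold higher number from compound 1 to compound 3 (0.29 log units; within the scatter) for methyl in place of hydrogen on the saturated chain carbon bound to the aromatic ring, so going from 4-methylphenyl to 4-ethylphenyl produces no difference beyond the usual scatter in this assay. No measurement shown here explains either step.

The change from compound 2 to compound 3 alters more than one feature of the aromatic group, so these compounds cannot separate the part played by the hydroxy group from that of the methyl group in 4-hydroxy-2-methylphenyl. They also leave open how far this position accepts change, as a longer chain such as propyl or butyl, an amine or a carboxylic acid in place of the ethyl group could give a quite different result.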